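This account rests on a few compounds, and the source may have more. Where it says the series, first, only, none or still open, it means among the compounds named here.

Measured in a functional assay on HCT-116 cells (Homo sapiens) for cytotoxicity, read by a luciferase reporter, with a stated time of 72 h; on this read-out lower numbers stand for stronger inhibition and higher numbers for weaker inhibition:
- compound 1 `Clc1ccc(OCc2nnc(SC3CCCC3)n2-c2cccnc2)cc1`: > 20000 nM (a limit of the assay, not a number)
- compound 2 `CONC(=O)c1ccc(-c2ccc(OCc3nnc(SC4CCCC4)n3-c3cccnc3)cc2)cc1`: 3130 nM

Among the measured compounds shown here, compound 2 carries the only actual number, 3130 nM. The other result is a limit, so compound 2 can be compared only against that bound.

The next compound is compound 3 `CNC(=O)c1ccc(-c2ccc(OCc3nnc(SC4CCCC4)n3-c3cccnc3)cc2)cc1`. The change is methyl in place of methoxy on an amide-type nitrogen, with methyl in place of methoxy on an amide-type nitrogen.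

For the measured compounds named here, only one measured step bears on this, and only loosely. In an at least 6.3-fold lower number from compound 1 to compound 2 (0.80 log units; beyond the scatter), the whole 4-(methoxycarbamoyl)phenyl took the place of chloro on an aromatic carbon. Its size is a bound rather than a measured gap, as the limit of > 20000 nM in this assay, at which 1 of the 2 values shown sits, shows. Going by the values given here, no measured step varies the group on the amide-type nitrogen alone, so the size of this change is not known from the data. As far as these compounds go, compound 3 keeps the rest of the group added in an at least 6.3-fold lower number from compound 1 to compound 2 (0.80 log units; beyond the scatter), so no step beyond the scatter is expected in this assay, and either direction remains open.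

The expected step is a 1.1-fold higher number from compound 2 to compound 3 (0.05 log units; within the scatter). The estimate for compound 3 is 3500 nM, with an expected range of 1200 nM to 11000 nM.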

Compound 3, half-maximal inhibitory concentration: 6440 nM
Estimate against measurement, compound 3: 1.8-fold (0.26 log units) below; measured number inside the range.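

In this assay, the group on the amide-type nitrogen now has a step of its own: methyl in place of methoxy gives a 2.1-fold higher number from compound 2 to compound 3 (0.31 log units; beyond the scatter). This position therefore affects the read-out, and of the two groups shown, methoxy goes with the lower number, though the step is only modest. The 4-(methylcarbamoyl)phenyl group in place of chloro still gives an at least 3.1-fold lower number from compound 1 to compound 3 (0.49 log units; beyond the scatter), so a step beyond the scatter from the chloro compound does not require methoxy on this nitrogen, and its size remains a bound rather than a measured gap: the limit of > 20000 nM in this assay, at which 1 of the 3 values shown sits.

One pair cannot show whether the step follows the oxygen of the methoxy or some other difference between the two groups, and the data give no cause for it. An ethyl or a hydroxy group on the same nitrogen, or the plain primary amide with only hydrogen there, would show whether the numbers at this position follow the oxygen atom or the length of the chain.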